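Acetyl replaces an ester side chain on the amine nitrogen

The source may report more compounds than this note shows. Statements on the series, on what has been measured and on what is new or still open speak of the compounds shown alone.

In a functional assay on A-375 cells (Homo sapiens) for cytotoxicity, read by MTT assay, with a stated time of 24 h (on this read-out higher numbers stand for weaker inhibition and lower numbers for stronger inhibition), compound 2 `CCOC(=O)CNC1=CC(=O)c2cc(C)c(C3=CC(=O)c4c(OC)cc(C)cc4C3=O)c(OC)c2C1=O` gives 570 nM. Compound 1 `COc1cc(C)cc2c1C(=O)C=C(c1c(C)cc3c(c1OC)C(=O)C(Nc1ccc(Cl)cc1)=CC3=O)C2=O` gives 630 nM, within the scatter of compound 2, so the two stand level at the low end of the numbers shown. Compound 3 `COc1cc(C)cc2c1C(=O)C(N)=C(c1c(C)cc3c(c1OC)C(=O)C(N)=CC3=O)C2=O` gives 1930 nM, a higher number that lies beyond the scatter of both.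

Compound 4 `COc1cc(C)cc2c1C(=O)C=C(c1c(C)cc3c(c1OC)C(=O)C(NC(C)=O)=CC3=O)C2=O` keeps the shared core but has acetyl in place of (ethoxycarbonyl)methyl on an amine nitrogen. Among the compounds with values here, one measured step bears directly on this nitrogen: a 1.1-fold lower number from compound 1 to compound 2 (0.04 log units; within the scatter), with (ethoxycarbonyl)methyl in place of 4-chlorophenyl. Within the data shown here, compound 3 differs from compound 2 in more than one place, so it gives no clean step. Even so, compound 3 at 1930 nM keeps the upper end of the range open. Among the measured compounds shown here, no acetyl compound has been measured yet, so this remains an extrapolation. The estimated step is a 1.2-fold higher number from compound 2 to compound 4 (0.09 log units; within the scatter), which means no change beyond the scatter is expected. The estimate for compound 4 is 700 nM, with an expected range of 300 nM to 1800 nM.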

Compound 4, half-maximal inhibitory concentration: 60 nM
The estimate for compound 4 lay 12-fold (1.07 log units) above the measured number, and the stated range ends above it.
By their numbers in this assay, from the lowest: compound 4; then compounds 2 and 1 (each within the scatter of the next); then compound 3.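

In this assay, the group on this amine nitrogen proves able to shift the number strongly. Acetyl gives a 9.5-fold lower number from compound 2 to compound 4 (0.98 log units; beyond the scatter) and an 11-fold lower number from compound 1 to compound 4 (1.02 log units; beyond the scatter), whereas the earlier exchange of 4-chlorophenyl for (ethoxycarbonyl)methyl gave only a 1.1-fold lower number from compound 1 to compound 2 (0.04 log units; within the scatter), so those first two groups had suggested that this position was insensitive to change. Nothing among the available data explains why acetyl stands apart from the other two groups.

Acetyl is the smallest of these three groups by heavy atoms and the only one that makes the nitrogen part of an acetamido group, so the compounds shown cannot separate those two differences. A plain ethyl group and a benzoyl group on the same nitrogen would help, since the first is small without a carbonyl and the second keeps the carbonyl on a larger group.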